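Benzyl ring substituent swap from compound 2 to compound 4

The source may hold more compounds than are shown below. What is called first, only, known or untested is meant among the compounds shown, and "the series" means these compounds.

Compound 2 `COc1ccc([C@@H]2CC(=O)c3c(O)cc(OCc4cn(Cc5ccccc5C(F)(F)F)nn4)cc3O2)cc1O` gives 12500 nM in a functional assay on RAW264.7 cells (Mus musculus) for inhibition, read by Griess assay, with stated times of 2 h and 24 h (on this read-out higher numbers stand for weaker inhibition and lower numbers for stronger inhibition), the second highest of three numbers. Within the data shown here, compound 1 `COc1ccc([C@@H]2CC(=O)c3c(O)cc(OCc4cn(Cc5cccc(Cl)c5)nn4)cc3O2)cc1O` gives 18200 nM in this assay; the one step along this line, a 1.5-fold lower number from compound 1 to compound 2 (0.16 log units; within the scatter), put 2-(trifluoromethyl)phenyl in place of 3-chlorophenyl on a saturated chain carbon bound to an aromatic nitrogen. Among the measured compounds shown here, compound 3 `CCCn1cc(COc2cc(O)c3c(c2)O[C@H](c2ccc(OC)c(O)c2)C/C3=N\O)nn1` gives 2340 nM, but it differs from compound 2 in more than one place and offers no step. Compound 4 `COc1ccc([C@@H]2CC(=O)c3c(O)cc(OCc4cn(Cc5ccccc5F)nn4)cc3O2)cc1O` differs from compound 2 by fluoro in place of trifluoromethyl on an aromatic carbon, on an aromatic carbon of a six-membered aromatic ring of carbon only, ortho to a large group. For the measured compounds named here, the only bearing step stayed within the scatter. The expected step is a 1.0-fold higher number from compound 2 to compound 4 (0.02 log units; within the scatter), none beyond the scatter. Compound 4 is estimated at 13000 nM, range 6000 nM to 30000 nM.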

Compound 4, half-maximal inhibitory concentration: 7320 nM
Beside the measured number, compound 4's estimate is 1.8-fold (0.25 log units) above it, and the stated range covers the measured number.
By their numbers in this assay, from the lowest: compound 3; then compounds 4, 2 and 1 (each within the scatter of the next, the first and the last beyond it).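

In this assay, the step of a 2.5-fold lower number from compound 1 to compound 4 (0.40 log units; beyond the scatter) is the first among these benzyl variants to pass the scatter, though only modestly, while the step of a 1.7-fold lower number from compound 2 to compound 4 (0.23 log units; within the scatter) stays within it. Compound 2 therefore lies within the scatter of both compound 1 and compound 4, and only the two ends of this short set separate. No evidence bears on the reason for these steps.

From the compounds shown here alone, whether an amine or a carboxylic acid on the phenyl group would shift the number further stays open. Also open, going by these compounds, is how the 2-fluorobenzyl group behaves on the core of compound 3.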